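Swapping the chlorine of compound 3 for a larger group

The compounds below may be only part of what the source reports. "The series", "measured", "known", "first", "only" and "open" are said of these compounds alone.

In a functional assay on SMMC-7721 cells (Homo sapiens) for cytotoxicity, read by MTT assay, with a stated time of 72 h (a higher number here means a weaker inhibitor, a lower number a stronger inhibitor), compound 1 `O=C(CCl)Nc1ccc(C(=O)/C=C/c2ccccc2)cc1` gives 12600 nM, compound 2 `O=C(CCl)Nc1ccc(C(=O)/C=C/c2ccc(F)cc2)cc1` gives 15100 nM and compound 3 `O=C(CCl)Nc1ccc(C(=O)/C=C/c2cccc(Cl)c2)cc1` gives 7760 nM. Compound 3 therefore stands within the scatter of both the others. Adding a chlorine atom to the aromatic end gives a 1.6-fold lower number from compound 1 to compound 3 (0.21 log units; within the scatter), and 3-chlorophenyl in place of 4-fluorophenyl gives a 1.9-fold lower number from compound 2 to compound 3 (0.29 log units; within the scatter). Fluoro in place of hydrogen on an aromatic carbon gives a 1.2-fold higher number from compound 1 to compound 2 (0.08 log units; within the scatter), which is equally small.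

Compound 4 `O=C(CSC(=S)N[C@H]1CCOC1=O)Nc1ccc(C(=O)/C=C/c2cccc(Cl)c2)cc1` changes a different part of the molecule: a group of 10 heavy atoms (5 carbon, 1 nitrogen, 2 oxygen, 2 sulfur; one five-membered non-aromatic ring with 1 hetero atom) in place of one chlorine atom, on a saturated chain carbon bound to a carbonyl carbon. None of the three measured steps touches that place, since all of them concern the aromatic end. They show how little the number moved there, but they give no direct measure of this much larger replacement. The data offer no evidence for a direction, so the best starting point is compound 3 itself at 7760 nM. The expected change is therefore no larger than the scatter, though this expectation is held loosely: a 1.3-fold lower number from compound 3 to compound 4 (0.11 log units; within the scatter). For compound 4 the estimate is 6000 nM, with a deliberately wide expected range from 1200 nM to 30000 nM.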

Compound 4, half-maximal inhibitory concentration: 39100 nM
Beside the measured number, compound 4's estimate is 6.5-fold (0.81 log units) below it; the whole stated range lies below it.
By their numbers in this assay, from the lowest: compounds 3, 1 and 2 (each within the scatter of the next); then compound 4.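

In this assay, going by these compounds alone, the earlier steps all concerned the aromatic end and none went beyond the scatter, so they left open whether any part of this series could move the number appreciably. Within the data shown here, replacing the chlorine on the saturated chain carbon bound to a carbonyl carbon gives a 5.0-fold higher number from compound 3 to compound 4 (0.70 log units; beyond the scatter) and is the first step here to go beyond the scatter, showing that this position responds more clearly than the aromatic changes did. The change is modest despite the much larger group, and compound 4 still gives a measured number rather than an assay limit, but nothing measured here explains the rise.

With only this one replacement at the position, the compounds shown do not separate the loss of the chlorine from the arrival of the new group, or the five-membered ring from the sulfur-containing link that carries it. A simple amine such as dimethylamine on that same carbon would test a much smaller replacement, while the group of compound 4 placed on compound 1 would show whether the step holds without the chlorine on the aromatic end.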